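This account rests on a few compounds, and the source may have more. Where it says the series, first, only, none or still open, it means among the compounds named here.

Working notes on amides of the shared core, read in an in vitro ADME assay on microsomes from liver (Mus musculus) for pharmacokinetics, read by LC-MS, with a stated time of 10 min, tested at 1 uM; on this read-out higher numbers stand for fast clearance and lower numbers for slow clearance. Compound 1 `CN1C[C@H](C(=O)Nc2ccccc2F)[C@@H](c2ccc(/C=C/C(=O)Nc3ccccc3N)cc2)C1` gives 67 mL/min/kg, compound 2 `CN1C[C@H](C(=O)Nc2ccc(F)c(Cl)c2)[C@@H](c2ccc(/C=C/C(=O)Nc3ccccc3N)cc2)C1` gives 34 mL/min/kg and compound 3 `CC(C)NC(=O)[C@H]1CN(C)C[C@@H]1c1ccc(/C=C/C(=O)Nc2ccccc2N)cc1` gives 12 mL/min/kg. Compound 3 is the lowest of the three, beyond the scatter from both others.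

The next compound is compound 4 `CN1C[C@H](C(=O)N2CCCCC2)[C@@H](c2ccc(/C=C/C(=O)Nc3ccccc3N)cc2)C1`, with this change: piperidin-1-yl in place of isopropylamino on a carbonyl carbon. Within the data shown here, no measured compound carries piperidin-1-yl, so the evidence is indirect. Among the measured compounds shown here, the only guide is the set of steps at this amide-type nitrogen: a 5.6-fold lower number from compound 1 to compound 3 (0.75 log units; beyond the scatter) and a 2.8-fold lower number from compound 2 to compound 3 (0.45 log units; beyond the scatter) are modest, while a 2.0-fold lower number from compound 1 to compound 2 (0.29 log units; within the scatter) stays within the scatter. Both compounds with a group larger than isopropylamino at this place read higher, compound 1 at 67 mL/min/kg and compound 2 at 34 mL/min/kg. A modest rise in this assay is therefore expected, though with wide uncertainty. The estimate amounts to a 2.0-fold higher number from compound 3 to compound 4 (0.30 log units; within the scatter). The expected value for compound 4 is 24 mL/min/kg, with an estimated range of 10 mL/min/kg to 55 mL/min/kg.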

Compound 4, clearance: 42 mL/min/kg
Compound 4: middle estimate off by 1.8-fold (0.24 log units), on the low side, and the stated range covers the measured number.
By their numbers in this assay, from the lowest: compound 3; then compounds 2, 4 and 1 (each within the scatter of the next).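

In this assay, the step to piperidin-1-yl is a 3.5-fold higher number from compound 3 to compound 4 (0.54 log units; beyond the scatter), so the low reading of compound 3 does not carry over to every saturated group on this carbonyl carbon. An aryl amide is also not required for a higher number, since the piperidin-1-yl amide shows a 1.2-fold higher number from compound 2 to compound 4 (0.09 log units; within the scatter) and a 1.6-fold lower number from compound 1 to compound 4 (0.20 log units; within the scatter), both steps within the scatter. Among the four compounds, isopropylamino alone stands apart at this place, and the change to piperidin-1-yl both adds a six-membered non-aromatic ring and removes the amide hydrogen.

The compounds shown cannot separate those two differences, and cyclohexylamino or dimethylamino on the same carbonyl carbon would pull them apart. The data shown offer no measurement that explains the step.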